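Hydrazone aryl variation on a shared quinazoline-derived urea core

This account rests on a few compounds, and the source may have more. Where it says the series, first, only, none or still open, it means among the compounds named here.

Working notes on a short series of compounds sharing one core and differing only in the aryl group attached to the hydrazone carbon. Compound 1 `O=C(N/N=C/c1ccc(F)cc1)Nc1cc2c(Nc3ccc(F)c(Cl)c3)ncnc2cc1O[C@H]1CCOC1` is the reference; in a functional assay on MCF7 cells (Homo sapiens) for cytotoxicity, read by MTT assay, with a stated time of 72 h (on this read-out lower numbers stand for stronger inhibition and higher numbers for weaker inhibition), compound 1 gives 28200 nM, the highest of the two numbers available. Compound 2 `N#Cc1ccc(/C=N/NC(=O)Nc2cc3c(Nc4ccc(F)c(Cl)c4)ncnc3cc2O[C@H]2CCOC2)cc1` carries a nitrile-bearing ring and has no result in this assay, recorded as "not determined" (no result reported). Compound 3 `O=C(N/N=C/c1cc(Br)c(O)c(Br)c1)Nc1cc2c(Nc3ccc(F)c(Cl)c3)ncnc2cc1O[C@H]1CCOC1` gives 5910 nM in this assay, and the step of a 4.8-fold lower number from compound 1 to compound 3 (0.68 log units; beyond the scatter) is the only measured one in the set.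

Compound 4 `O=C(N/N=C/c1ccc(O)cc1O)Nc1cc2c(Nc3ccc(F)c(Cl)c3)ncnc2cc1O[C@H]1CCOC1` has not yet been measured. It differs from compound 1 by 2,4-dihydroxyphenyl in place of 4-fluorophenyl on a carbon with a double bond to nitrogen. The step from compound 1 to compound 3 bears on this change, since both replace the 4-fluorophenyl with a hydroxyl-bearing phenyl, and it was modest in size. A step of comparable direction is therefore expected for compound 4, and the estimate for compound 4 in this assay is 10000 nM, with a range from 3000 nM to 30000 nM, corresponding to an expected step of a 2.8-fold lower number from compound 1 to compound 4 (0.45 log units; beyond the scatter).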

Compound 4, half-maximal inhibitory concentration: 5350 nM
For compound 4 the middle estimate is 1.9-fold (0.27 log units) above the measured one; the range from low to high includes it.
By their numbers in this assay, from the lowest: compounds 4 and 3 (each within the scatter of the next); then compound 1.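

In this assay, a second hydroxyl-bearing aryl group on the carbon with a double bond to nitrogen also gives a lower number than 4-fluorophenyl (a 5.3-fold lower number from compound 1 to compound 4 (0.72 log units; beyond the scatter)), so the lower number is not confined to 3,5-dibromo-4-hydroxyphenyl. The two replacements cannot be separated (a 1.1-fold lower number from compound 3 to compound 4 (0.04 log units; within the scatter)), which shows that a replacement without bromine can match the dibromo compound at this position. No measurement here accounts for either result.

The compounds shown leave open whether the hydroxyl groups themselves matter, as a methoxy group, an amine or a carboxylic acid on the same ring would test. Steps involving compound 2 cannot be read, so the nitrile-bearing ring remains uninformative.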